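The compounds below may be only part of what the source reports. "The series", "measured", "known", "first", "only" and "open" are said of these compounds alone.

Within the data shown here, compound 2 `O=c1[nH]/c(=N\OCCCc2cccc(F)c2)ccn1[C@@H]1O[C@H](COP(=O)(O)OP(=O)(O)OP(=O)(O)O)[C@@H](O)[C@H]1O` gives the lowest number of the three measured so far: in a functional assay on 1321-N1 cells for agonist activity at P2Y purinoceptor 4 (Homo sapiens), read by scintillation counting and inositol phosphate accumulation (on this read-out lower numbers stand for an effect already at smaller amounts and higher numbers for an effect only at larger amounts of compound), compound 2 gives 100 nM. Compound 1 `O=C(O)CCCO/N=c1/ccn([C@@H]2O[C@H](COP(=O)(O)OP(=O)(O)OP(=O)(O)O)[C@@H](O)[C@H]2O)c(=O)[nH]1` gives 470 nM and compound 3 `O=c1[nH]/c(=N\OCCCc2cccnc2)ccn1[C@@H]1O[C@H](COP(=O)(O)OP(=O)(O)OP(=O)(O)O)[C@@H](O)[C@H]1O` gives 300 nM; the steps read a 4.7-fold lower number from compound 1 to compound 2 (0.67 log units; beyond the scatter) and a 3.0-fold higher number from compound 2 to compound 3 (0.48 log units; beyond the scatter), while a 1.6-fold lower number from compound 1 to compound 3 (0.19 log units; within the scatter). Compound 4 `O=c1[nH]/c(=N\OCCCc2ccsc2)ccn1[C@@H]1O[C@H](COP(=O)(O)OP(=O)(O)OP(=O)(O)O)[C@@H](O)[C@H]1O` differs from compound 2 by thiophen-3-yl in place of 3-fluorophenyl on a saturated chain carbon, three bonds along the chain from an oxygen. The closest guide is the step from compound 2 to compound 3, where pyridin-3-yl replaced 3-fluorophenyl on a saturated chain carbon, three bonds along the chain from an oxygen; thiophen-3-yl likewise enters with one hydrogen-bond acceptor, so a modest rise is expected, a 1.8-fold higher number from compound 2 to compound 4 (0.26 log units; within the scatter). Compound 4 is therefore expected at about 180 nM, in the range 80 nM to 500 nM.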

Compound 4, half-maximal effective concentration: 20 nM
Compound 4: middle estimate off by 9.0-fold (0.95 log units), on the high side; the measured number lies below the stated range.
By their numbers in this assay, from the lowest: compound 4; then compound 2; then compounds 3 and 1 (each within the scatter of the next).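

In this assay, thiophen-3-yl at the end of this chain gives the lowest number in the series, with a 5.0-fold lower number from compound 2 to compound 4 (0.70 log units; beyond the scatter), a 15-fold lower number from compound 3 to compound 4 (1.18 log units; beyond the scatter) and a 24-fold lower number from compound 1 to compound 4 (1.37 log units; beyond the scatter). Compound 4 thus shows that a five-membered aromatic ring with a sulfur atom serves better at this place than either six-membered aromatic ring shown, so the aryl rings here are not interchangeable. Nothing measured bears on why this change lowers the number.

As far as these compounds go, whether the sulfur or the ring size carries the step remains open. Also open, from the compounds shown here alone, are thiophen-2-yl, furan-3-yl, and the shorter 2-(thiophen-3-yl)ethyl chain.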